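Bromo substitution on the indole in a bis-indole series

A few compounds are considered here, and "the series" means these few. Any claim that something is new, unique, unknown or untested is made for them only; others in the source may bear on it.

Measured compounds:
Compound 1 `O=C1NC[C@@H](c2c[nH]c3ccccc23)N[C@H]1c1c[nH]c2ccccc12` gives 9.64 ug/mL in an ADME assay on SK-OV-3 cells (Homo sapiens) for cytotoxicity; on this read-out lower numbers stand for an effect already at smaller amounts and higher numbers for an effect only at larger amounts of compound.
Compound 2 `O=C(C1=NC(c2c[nH]c3ccccc23)CN1)c1c[nH]c2cc(Br)ccc12` reaches only the limit > 30 ug/mL in this assay; this is a limit, not a number.
Compound 3 `O=C(C1=NC(c2c[nH]c3cc(Br)ccc23)CN1)c1c[nH]c2cc(Br)ccc12` gives 4.81 ug/mL in this assay.

Among the compounds with values here, the one measured step within a single core runs from compound 2 to compound 3: bromo in place of hydrogen on an aromatic carbon. It made an at least 6.2-fold lower number from compound 2 to compound 3 (0.79 log units; beyond the scatter). Since the value of compound 2 sits at the limit of > 30 ug/mL in this assay, at which 1 of the 3 values shown sits, the true size of that step is open at the upper end. Compound 1 and compound 3 lie within the scatter of each other, so no order between them is read.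

The difference between the core of compound 1 and the core of compound 2 is not broken down here.

Compound 4 `O=C1NC[C@@H](c2c[nH]c3cc(Br)ccc23)N[C@H]1c1c[nH]c2ccccc12` differs from compound 1 by bromo in place of hydrogen on an aromatic carbon. The place is described in the same words as for the step from compound 2 to compound 3, so this is the same change carried onto the core of compound 1.

For compound 4 a step of a 2.1-fold lower number from compound 1 to compound 4 (0.33 log units; beyond the scatter) is expected, set beside the measured at least 6.2-fold lower number from compound 2 to compound 3 (0.79 log units; beyond the scatter). The expectation rests on that single step and is held smaller and wider than it, as the earlier step starts from a limit and the change has been seen only once among the compounds shown. The estimate for compound 4 in this assay is 4.5 ug/mL, with a range from 1.5 ug/mL to 10 ug/mL.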

Compound 4, concentration for half-maximal effect: 6 ug/mL
Estimate against measurement, compound 4: 1.3-fold (0.12 log units) below; measured number inside the range.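

In this assay, bromo in place of hydrogen on an aromatic carbon gives a 1.6-fold lower number from compound 1 to compound 4 (0.21 log units; within the scatter), so on the core of compound 1 the change has no readable effect, and the larger step on the other core does not carry over at its full size: the same change on two cores in this assay, an at least 6.2-fold lower number (0.79 log units; beyond the scatter) from compound 2 to compound 3 and a 1.6-fold lower number (0.21 log units; within the scatter) from compound 1 to compound 4, at least 3.8-fold (0.58 log units) apart, beyond the scatter of two such steps

The value of compound 2 is a limit and not a number, so the step on its core has no known upper end, and the gap between the two steps is likewise open at that end: the limit of > 30 ug/mL in this assay, at which 1 of the 4 values shown sits.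

These two pairs show that the same change need not give the same step on these two cores, but they give no rule for any further core and no reason for the gap.

As far as these compounds go, whether a chloro, a methoxy or an amine on the same aromatic carbon would follow the step on the core of compound 1 or the one on the core of compound 2 remains open. Also open, from the compounds shown here alone, is whether the gap between the two steps would recur with a second pair on each core, since each core offers a single pair here.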